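Methoxy on compound 2: expected shift in cytotoxicity

The compounds below may be only part of what the source reports. "The series", "measured", "known", "first", "only" and "open" are said of these compounds alone.

Measured so far:
- compound 1 `CCOC(=O)/C=C/c1ccc(OCc2nc(C)c(C)nc2C)c(O)c1` gives 139000 nM
- compound 2 `CCOC(=O)/C=C/c1ccccc1OCc1nc(C)c(C)nc1C` gives 1540000 nM

In a functional assay on ECV-304 cells (Homo sapiens) for cytotoxicity, read by MTT assay, with stated times of 24 h and 12 h (on this read-out lower numbers stand for an effect already at smaller amounts and higher numbers for an effect only at larger amounts of compound), compound 2 gives 1540000 nM as the higher of the two numbers, and its gap to compound 1 lies beyond the scatter.

Compound 3 `CCOC(=O)/C=C/c1cccc(OC)c1OCc1nc(C)c(C)nc1C` differs from compound 2 by methoxy in place of hydrogen on an aromatic carbon, ortho to a large group and meta to a 2-(ethoxycarbonyl)ethenyl group (methoxy in place of hydrogen on an aromatic carbon).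

Going by the values given here, no measured pair shows this change alone, so the expectation is loose. Among the compounds with values here, the only lower number so far belongs to compound 1 at (139000 nM), which leaves room for a moderate move toward lower numbers, though no change beyond the scatter remains possible. The expected move is (a 3.1-fold lower number from compound 2 to compound 3 (0.49 log units; beyond the scatter)). For compound 3 the estimated value is (500000 nM), with an expected range of (90000 nM) to (2000000 nM).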

Compound 3, half-maximal effective concentration: 3040000 nM
Estimate against measurement, compound 3: 6.1-fold (0.78 log units) below; measured number above the stated range.
By their numbers in this assay, from the lowest: compound 1; then compounds 2 and 3 (each within the scatter of the next).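

In this assay, going by these compounds alone, methoxy in place of hydrogen on an aromatic carbon, ortho to a large group and meta to a 2-(ethoxycarbonyl)ethenyl group, gives the first single-place step (a 2.0-fold higher number from compound 2 to compound 3 (0.30 log units; within the scatter)). At this position, then, the read-out of the methoxy compound cannot be separated from that of the hydrogen compound, and this change gives no move toward lower numbers that stands clear of the scatter. No measurement on hand bears on the reason for this result.

On these data alone, whether an amine, a carboxylic acid or a longer chain such as butoxy at this same position would give a step beyond the scatter remains open. Also open, as far as these compounds go, is whether methoxy elsewhere on the six-membered aromatic ring would read the same way.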